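Working notes: replacing one side group of compound 1

This account rests on a few compounds, and the source may have more. Where it says the series, first, only, none or still open, it means among the compounds named here.

In a functional assay on MDA-MB-231 cells (Homo sapiens) for cytotoxicity, read by MTT assay, with a stated time of 72 h (on this read-out lower numbers stand for stronger inhibition and higher numbers for weaker inhibition), compound 1 (`O=C1c2c[n+]([O-])c3ccccc3c2C(=O)c2c1c1ccccc1n2Cc1cn([C@H]2O[C@H](CO)[C@@H](O)[C@H]2O)nn1`) gives 1700 nM and compound 2 (`CCCCN1CCN(CCCCn2c3c(c4ccccc42)C(=O)c2c[n+]([O-])c4ccccc4c2C3=O)CC1`) gives 900 nM within the scatter of compound 1. Compound 3 (`CC1(C)OC[C@H](Cn2cc(Cn3c4c(c5ccccc53)C(=O)c3c[n+]([O-])c5ccccc5c3C4=O)nn2)O1`), not yet measured, carries (2,2-dimethyl-1,3-dioxolan-4-yl)methyl in place of 3,4-dihydroxy-5-(hydroxymethyl)oxolan-2-yl on an aromatic nitrogen. For the measured compounds named here, no measured pair differs in one place, and compound 2 at 900 nM is the only guide. A step within the scatter, tilted toward a lower number, is expected (a 1.7-fold lower number from compound 1 to compound 3 (0.23 log units; within the scatter)) in this assay for this change. Compound 3 is estimated at 1000 nM with an expected range from 350 nM to 3000 nM on this read-out.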

Compound 3, half-maximal inhibitory concentration: 530 nM
For compound 3 the middle estimate is 1.9-fold (0.28 log units) above the measured one; measured number inside the range.
By their numbers in this assay, from the lowest: compounds 3, 2 and 1 (each within the scatter of the next, the first and the last beyond it).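

At this position, an aromatic nitrogen of the five-membered ring with 3 nitrogen, this assay now gives a first readable step: (2,2-dimethyl-1,3-dioxolan-4-yl)methyl in place of 3,4-dihydroxy-5-(hydroxymethyl)oxolan-2-yl gives a 3.2-fold lower number from compound 1 to compound 3 (0.51 log units; beyond the scatter) on the same core. The entering group has no hydrogen-bond donors, so the number does not depend on keeping the donors of the leaving group. Nothing available ties the step to any one difference between the two groups. Open, from the compounds shown here alone, is whether an open-chain diol, an amine or a carboxylic acid on this nitrogen would hold the lower number, and whether the opposite configuration at the single stereocentre would do so.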